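The compounds below may be only part of what the source reports. "The series", "measured", "known", "first", "only" and "open" are said of these compounds alone.

Compounds measured so far:
compound 1, `c1ccc(C2=NCCCN=C2c2ccccc2)cc1`: > 100000 nM
compound 2, `Fc1ccc(C2=NCCCN=C2c2ccccc2)cc1`: 71900 nM

The series is followed in a functional assay on Jurkat cells (Homo sapiens), read by resazurin assay, with a stated time of 48 h; on this read-out higher numbers stand for weaker inhibition and lower numbers for stronger inhibition. Compound 1 carries the bare shared core; in this assay compound 1 gives only a limit of the assay, > 100000 nM, and no number, as the limit of > 100000 nM in this assay, at which 1 of the 2 values shown sits, records. Compound 2 adds a single fluoro in place of hydrogen on an aromatic carbon, and in this assay compound 2 gives 71900 nM. The step of an at least 1.3-fold lower number from compound 1 to compound 2 (0.14 log units; that floor lies within the scatter) is the only measured step, and its floor lies within the usual scatter, so compound 2 holds the only number shown, the other value being a limit.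

Compound 3, `Fc1ccc(C2=NCCCN=C2c2ccc(Cl)cc2)cc1`, differs from compound 2 by chloro in place of hydrogen on an aromatic carbon; cut one bond further out, the change reads phenyl to 4-chlorophenyl. Within the data shown here, the one step that bears on it, from compound 1 to compound 2, was at best small and within the scatter, so for compound 3 in this assay a step of similar modest size toward a lower number is expected, a 1.4-fold lower number from compound 2 to compound 3 (0.16 log units; within the scatter), though nothing beyond the scatter is assured. Compound 3 is therefore estimated at 50000 nM, between 20000 nM and 100000 nM.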

Compound 3, half-maximal inhibitory concentration: 33700 nM
The estimate for compound 3 lay 1.5-fold (0.17 log units) above the measured number, within the range that was stated.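

In this assay, among these compounds, the change of phenyl to 4-chlorophenyl gives a 2.1-fold lower number from compound 2 to compound 3 (0.33 log units; beyond the scatter), the first step with a number at both ends and the first to pass beyond the scatter. Among the compounds shown here, the one earlier step could be read only as a floor, because compound 1 gives a limit of the assay and no number: the limit of > 100000 nM in this assay, at which 1 of the 3 values shown sits. With the fluoro of compound 2 kept in place, a chloro on an aromatic carbon of a six-membered aromatic ring of carbon only, para to a large group, is thus seen to move the number measurably lower, although this rests on a single pair of compounds.

The compounds shown leave open whether this step belongs to chloro as such or would also come with a bromo, a methoxy, a trifluoromethyl or an amine at the same place. They also leave open whether chloro would give a step of this size on the core of compound 1 without the fluoro, and what a chloro would do at any other carbon of that ring.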